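The source may hold more compounds than are shown below. What is called first, only, known or untested is meant among the compounds shown, and "the series" means these compounds.

In a functional assay on the whole organism for inhibition, with Mus musculus as the target (on this read-out higher numbers stand for an effect only at larger amounts of compound and lower numbers for an effect already at smaller amounts), compound 1 (`CCCCNC(=O)Nc1cccc2c1CN(C)CC2c1ccccc1`) gives about 40 mg/kg and compound 2 (`CN1Cc2c(NC(=O)OCc3ccccc3)cccc2C(c2ccccc2)C1`) gives about 15 mg/kg as the lower of the two numbers. Compound 3 (`CCNCC(=O)Nc1cccc2c1CN(C)CC2c1ccccc1`) has not yet been measured and carries (ethylamino)methyl in place of benzyloxy on a carbonyl carbon as its difference from compound 2. Among the measured compounds shown here, the one measured step that bears on this change, a 2.7-fold lower number from compound 1 to compound 2 (0.43 log units; beyond the scatter) with benzyloxy entering, was modest. With benzyloxy now leaving, a modest step to a higher number is expected, estimated as a 2.0-fold higher number from compound 2 to compound 3 (0.30 log units; within the scatter) on this single precedent. In this assay compound 3 is expected at 30 mg/kg within an estimated range from 10 mg/kg to 90 mg/kg overall.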

Compound 3, dose for half-maximal effect: 47 mg/kg
Beside the measured number, compound 3's estimate is 1.6-fold (0.19 log units) below it, and the stated range covers the measured number.
By their numbers in this assay, from the lowest: compound 2; then compounds 1 and 3 (each within the scatter of the next).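

In this assay, replacing benzyloxy on the carbonyl carbon with (ethylamino)methyl reverses the earlier gain (a 3.1-fold higher number from compound 2 to compound 3 (0.50 log units; beyond the scatter)), so the low number of compound 2 now stands apart from two different groups rather than one. These two cannot be separated (a 1.2-fold higher number from compound 1 to compound 3 (0.07 log units; within the scatter)), which shows that butylamino and (ethylamino)methyl read alike in this place. Nothing given here explains why benzyloxy differs from both.

The compounds shown leave open whether the ring of benzyloxy or its oxygen goes with the lower number. A benzylamino group or a simple methoxy group on this carbonyl carbon would bear on that question.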